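The compounds below may be only part of what the source reports. "The series", "measured", "known", "first", "only" and "open" are said of these compounds alone.

In a functional assay on HL-60 cells (Homo sapiens) for antiproliferative activity, with a stated time of 24 h (on this read-out lower numbers stand for stronger inhibition and higher numbers for weaker inhibition), three compounds have been measured so far:

compound 1 `NC(=O)c1c(NC(=O)c2ccccc2Cl)sc2c1CCN(Cc1cc(Cl)cc(Cl)c1)C2` gives 15800 nM
compound 2 `Cc1ccc(C(=O)Nc2sc3c(c2C(N)=O)CCN(Cc2c(Cl)cccc2Cl)C3)cc1` gives 10000 nM
compound 3 `NC(=O)c1c(NC(=O)c2ccccc2F)sc2c1CCN(Cc1cccc(Cl)c1)C2` gives 19800 nM

On the numbers shown, compound 1 holds the second highest of the three. Compound 3 lies nearest to it and compound 2 furthest, yet both gaps fall within the usual scatter of repeated measurements, so the three compounds cannot be ordered against one another; all three sit in one narrow band of weak inhibition.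

Compound 4 `NC(=O)c1c(NC(=O)c2ccccc2Cl)sc2c1CCN(C(=S)Nc1c(Cl)cccc1Cl)C2` is the next compound to be measured. It differs from compound 1 in a single place: a group of 11 heavy atoms (7 carbon, 1 nitrogen, 1 sulfur, 2 chlorine; one six-membered aromatic ring of carbon only) in place of a group of 9 heavy atoms (7 carbon, 2 chlorine; one six-membered aromatic ring of carbon only), on an amine nitrogen in a ring

Within the data shown here, no pair of measured compounds isolates this change, so there is no measured step to lean on, and the three numbers that do exist all lie close together. The expectation for this assay is therefore a step from compound 1 to compound 4 of a 1.2-fold lower number from compound 1 to compound 4 (0.08 log units; within the scatter), not beyond the scatter in either direction. Compound 4 is estimated at 13000 nM, with a range from 3500 nM to 50000 nM.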

Compound 4, half-maximal inhibitory concentration: 3950 nM
Estimate against measurement, compound 4: 3.3-fold (0.52 log units) above, within the range that was stated.
By their numbers in this assay, from the lowest: compound 4; then compounds 2, 1 and 3 (each within the scatter of the next).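

In this assay, the group on the amine nitrogen in the ring proves able to move the number: with 3,5-dichlorobenzyl replaced by a group that brings sulfur, a further nitrogen, a double bond outside aromatic rings, a hydrogen-bond donor and a hydrogen-bond acceptor, the result is a 4.0-fold lower number from compound 1 to compound 4 (0.60 log units; beyond the scatter). Among these compounds, the earlier compounds offered no step at this position, so this is the first change there that can be read, and it lies beyond the scatter, though it rests on this single pair. Nothing available explains the step.

The compounds shown leave open which part of the entering group matters, since no compound carries oxygen in place of its sulfur. They also leave open whether a simple acetyl group on that nitrogen would give a comparable step.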